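The compounds below may be only part of what the source reports. "The series", "measured", "known", "first", "only" and "open" are said of these compounds alone.

Three compounds of a shared quinoline-type core were tested in a toxicity assay on HepG2 cells (Homo sapiens) for inhibition, read by CellTiter-Glo, with a stated time of 48 h; a lower number here means a stronger inhibitor, a higher number a weaker inhibitor. Compound 1 `COc1ccc2nc(C)cc(NC(=O)C(=O)Nc3cc(C)cc(C)c3)c2c1` gives only a limit of the assay, > 100000 nM. Compound 2 `COc1ccc2nc(C)cc(OCC(=O)Nc3c(C)cccc3C)c2c1` likewise gives only a limit, > 100000 nM. Compound 3 `COc1ccc2nc(C)cc(OCC(=O)Nc3ccc(Cl)c(C(F)(F)F)c3)c2c1` gives a measured number, 79400 nM. Compound 2 therefore stands where most of the values shown stand: at the limit, with no number of its own, a position shared by two of the three compounds (the limit of > 100000 nM in this assay, at which 2 of the 3 values shown sit).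

Compound 4 `COc1ccc2nc(C)cc(OCC(=O)NNC(=O)c3ccncc3)c2c1` has not yet been measured in this assay. It differs from compound 2 in one place (((pyridin-4-yl)carbonyl)amino in place of 2,6-dimethylphenyl on an amide-type nitrogen). For the measured compounds named here, no step between two measured compounds here shows what such a change does, so there is nothing to point to for its size. Given that compound 2 reached only a limit, compound 4 is expected to stay near that limit as well, with a step of about a number no higher from compound 2 to compound 4 (the limit leaves the size open). The expected value for compound 4 is 100000 nM, within a range from 40000 nM to 250000 nM.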

Compound 4, half-maximal inhibitory concentration: > 100000 nM
Compound 4: only a limit was reported; the forecaster's own chance of this, stated with the estimate: 75%; the middle value lies on the limit itself.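

In this assay, compound 2 and compound 4 both give only a limit, not a number, so the step between them cannot be read: the limit of > 100000 nM in this assay, at which 3 of the 4 values shown sit. Still open, going by these compounds, is whether ((pyridin-4-yl)carbonyl)amino in place of 2,6-dimethylphenyl changes the true value at all, and in which direction.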